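This account rests on a few compounds, and the source may have more. Where it says the series, first, only, none or still open, it means among the compounds named here.

In an ADME assay on J774.A1 cells (Mus musculus) for inhibition, read by MTT assay, with a stated time of 72 h (a lower number here means that less compound is needed, a higher number that more compound is needed for the effect), three compounds sharing one core have entries so far. Compound 1 `CNc1nc(NC(C)C)nc2ccccc12` stands as "not determined" (no result reported), so it offers no comparison. Compound 2 `CC(C)Nc1nc(Nc2ccccc2)c2ccccc2n1`, with phenyl on a nitrogen on an aromatic ring, gives 12000 nM. Compound 3 `CC(C)Nc1nc(NC(C)C)c2ccccc2n1` gives > 30000 nM, which is a limit of the assay and not a number. Compound 3 therefore has no exact position and stands at the limit of > 30000 nM in this assay, at which 1 of the 3 values shown sits.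

Compound 4 `CC(C)Nc1nc(NC2CC2)c2ccccc2n1` has not been measured, and its structure differs by a single swap: cyclopropyl in place of isopropyl on a nitrogen on an aromatic ring. Going by the values given here, the only measured step at this place is an at least 2.5-fold higher number from compound 2 to compound 3 (0.39 log units; beyond the scatter), where isopropyl replaced phenyl. As far as these compounds go, that step does not test cyclopropyl directly, and it ends at a limit, so its full size is unknown. Among the compounds with values here, with no measured step for this swap, the reading of compound 3 at > 30000 nM remains the best guide, and no change beyond the scatter is expected in this assay. The expected step is a number no higher from compound 3 to compound 4 (the limit leaves the size open). Compound 4 is estimated at 30000 nM, with an expected range from 12000 nM to 70000 nM.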

Compound 4, half-maximal effective concentration: 31000 nM
Beside the measured number, compound 4's estimate is 1.0-fold (0.01 log units) below it; the measured number falls inside the stated range.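

In this assay, replacing phenyl on this nitrogen can now be sized with a full number at both ends: a 2.6-fold higher number from compound 2 to compound 4 (0.41 log units; beyond the scatter). Isopropyl in compound 3 and cyclopropyl in compound 4 both carry no aromatic ring, and both sit on the higher side of compound 2, so among these three compounds only the phenyl compound has a clearly lower number. The step from compound 3 to compound 4 cannot be read, since the value of compound 3 is a limit and not a number: the limit of > 30000 nM in this assay, at which 1 of the 4 values shown sits.

As far as these compounds go, whether closing isopropyl into the three-membered ring of cyclopropyl changes the number at all therefore stays open. Also open, from the compounds shown here alone, is how a longer chain such as n-butyl, or a chain ending in a carboxylic acid, would read at this nitrogen.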